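Dropping a Methoxy Group from a Weak Hydroxamic Acid

A few compounds are considered here, and "the series" means these few. Any claim that something is new, unique, unknown or untested is made for them only; others in the source may bear on it.

Measured compounds:
- compound 1 `O=C(CCCCCCC(=O)Nc1ccccc1C(=O)NO)Nc1ccccc1`: 550 nM
- compound 2 `COc1cccc(/C=C/c2ccc(C(=O)NO)o2)c1O`: 42800 nM

Both measured compounds were tested in an assay on isolated protein for inhibition of histone deacetylase 4 (Homo sapiens), read by fluorescence; on this read-out lower numbers stand for stronger inhibition and higher numbers for weaker inhibition. Compound 1 gives 550 nM, the lower of the two numbers. Compound 2 gives 42800 nM, the highest number of the two, and the gap between compound 1 and compound 2 is far wider than the usual scatter of repeated measurements, so compound 2 is the weaker inhibitor of this pair. Compound 1 and compound 2 differ in many places at once, so no single structural change can be read off from that comparison.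

The next compound, compound 3 `O=C(NO)c1ccc(/C=C/c2ccccc2O)o1`, is built from compound 2 by one change: hydrogen in place of methoxy on an aromatic carbon. This is a small change, and no comparison between two measured compounds is available to show what such a change does in this assay. Without such a guide, the default expectation is a step from compound 2 to compound 3 of a 1.1-fold lower number from compound 2 to compound 3 (0.03 log units; within the scatter), in no particular direction and not beyond the scatter. Compound 3 is therefore expected to come out near 40000 nM, somewhere between 10000 nM and 160000 nM.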

Compound 3, half-maximal inhibitory concentration: 74200 nM
Compound 3: middle estimate off by 1.9-fold (0.27 log units), on the low side, within the range that was stated.
By their numbers in this assay, from the lowest: compound 1; then compounds 2 and 3 (each within the scatter of the next).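

In this assay, removing the methoxy group from this aromatic carbon, ortho to a hydroxy group, and leaving hydrogen in its place gives a 1.7-fold higher number from compound 2 to compound 3 (0.24 log units; within the scatter). This is the only pair shown that differs in one place, and it offers a first direct reading of this position: losing the methoxy group's two heavy atoms produces no difference that can be told apart from the ordinary variation between repeated measurements, so compound 2 and compound 3 cannot be ranked against each other. No other measurement bears on what lies behind this result.

Going by these compounds, what remains open is whether any other group on this carbon, such as an amine, a carboxylic acid or a longer chain like ethoxy, would move the number beyond that variation in either direction, since hydrogen and methoxy are the only two options compared here. Also unsettled is whether the same swap would give a similarly small step on another aromatic carbon of this ring or on a different core.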